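This account rests on a few compounds, and the source may have more. Where it says the series, first, only, none or still open, it means among the compounds named here.

Measured in a functional assay on MGC-803 cells (Homo sapiens) for inhibition, read by MTT assay, with a stated time of 48 h; a higher number here means a weaker inhibitor, a lower number a stronger inhibitor:
- compound 1 `COCC(=O)N(Cc1ccc(OC)c(O)c1)c1cc(OC)c(OC)c(OC)c1`: 79 nM
- compound 2 `COc1ccc(CN(C(=O)C(C)Br)c2cc(OC)c(OC)c(OC)c2)cc1O`: 120 nM
- compound 3 `C/C=C/C(=O)N(Cc1ccc(OC)c(N)c1)c1cc(OC)c(OC)c(OC)c1`: 150 nM

Compound 2 lies within the scatter of both other compounds, so its value does not set it apart from either. For the measured compounds named here, the one measured step that bears directly on this position is a 1.5-fold higher number from compound 1 to compound 2 (0.18 log units; within the scatter). Here, 1-bromoethyl replaces methoxymethyl on a carbonyl carbon, and this assay barely registers the exchange.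

The next compound is compound 4 `CCC/C=C/C(=O)N(Cc1ccc(OC)c(O)c1)c1cc(OC)c(OC)c(OC)c1`, and the change from compound 2 is pent-1-en-1-yl in place of 1-bromoethyl on a carbonyl carbon. Going by the values given here, no measured step covers this exchange. The nearest evidence is compound 3, at 150 nM, which also has a double bond in the chain on its carbonyl but carries an amino group where compound 2 has a hydroxyl. Going by these compounds, its value shows that such a chain is compatible with a number of this size, although the longer pent-1-en-1-yl chain remains untested. No step beyond the scatter is therefore expected, with any drift more likely towards a higher number. The expected change is a 1.5-fold higher number from compound 2 to compound 4 (0.18 log units; within the scatter). For compound 4 the estimated value is 180 nM, with an expected range of 60 nM to 500 nM.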

Compound 4, half-maximal inhibitory concentration: 70 nM
Beside the measured number, compound 4's estimate is 2.6-fold (0.41 log units) above it, and the stated range covers the measured number.
By their numbers in this assay, from the lowest: compounds 4, 1, 2 and 3 (each within the scatter of the next, the first and the last beyond it).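

In this assay, putting pent-1-en-1-yl on the carbonyl carbon in place of 1-bromoethyl gives a 1.7-fold lower number from compound 2 to compound 4 (0.23 log units; within the scatter), and putting it there in place of methoxymethyl gives a 1.1-fold lower number from compound 1 to compound 4 (0.05 log units; within the scatter). Together with the earlier step between compound 1 and compound 2, this means that none of the three groups at this position can be told apart from another in this assay, even though they differ in size and make-up. Pent-1-en-1-yl consists of carbon alone, so the position also holds a number of this size with neither the bromine of compound 2 nor the oxygen of the methoxymethyl group of compound 1, and no measurement offers an explanation for this tolerance.

The compounds shown do not tell whether the double bond plays any part, since a saturated pentyl chain on the same carbonyl carbon would be needed to separate it from chain length. They also leave open how far the position's tolerance extends, for instance to a much longer alkyl chain, a phenyl ring, or a chain ending in an amine or a carboxylic acid.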